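The compounds below may be only part of what the source reports. "The series", "measured", "known", "first", "only" and "open" are said of these compounds alone.

Compound 1 `c1ccc(Sc2nn3cc(-c4cc5ccccc5o4)nc3s2)cc1` is given as "not determined" (no result reported) in an assay for antagonist activity at proteinase-activated receptor 4 (Homo sapiens), with stated times of 5 min, 50 s and 15 min, in the presence of a further agent that is not named here (a higher number here means a weaker inhibitor, a lower number a stronger inhibitor), and so has no number of its own; it stands outside the measured set. Two relatives carry a methoxy group on the shared core: compound 2 `COc1nn2cc(-c3cc4c(OC)ccc(OC)c4o3)nc2s1` gives 2100 nM and compound 3 `COc1nn2cc(-c3cc4c(OC)cccc4o3)nc2s1` gives 350 nM in this assay. Going by the values given here, the only step with a figure, a 6.0-fold lower number from compound 2 to compound 3 (0.78 log units; beyond the scatter), concerns the fused benzofuran part and not the position changed here. Compound 4 `Cc1nn2cc(-c3cc4ccccc4o3)nc2s1` arises from compound 1 by methyl in place of phenylsulfanyl on an aromatic carbon. Among the compounds with values here, no measured step bears directly on this exchange, so the direction of the change in this assay is open. On the values of compounds 2 and 3 alone, compound 4 is expected to land near 600 nM, between 120 nM and 3500 nM.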

Compound 4, half-maximal inhibitory concentration: > 30000 nM
Compound 4 ended at the assay's limit (the forecaster's own chance of this, stated with the estimate: 15%); middle value at least 50-fold (1.69 log units) from the limit.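

Going by these compounds alone, no step between compound 1 and compound 4 can be read: compound 1 has no number, and compound 4 stands only at a limit of the assay. Going by these compounds, what exchanging phenylsulfanyl for methyl does to inhibition stays open.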